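This account rests on a few compounds, and the source may have more. Where it says the series, first, only, none or still open, it means among the compounds named here.

Compound 1 (`NCC(=O)Nc1ccc(Cl)cc1C(=O)c1ccccc1`): in a functional assay on the whole organism (strain CF-1) with Mus musculus as the target (a lower number here means that less compound is needed, a higher number that more compound is needed for the effect), compound 1 gives 32 mg/kg.
Compound 2 (`CN(C)Cc1nnc(-c2ccco2)n1-c1ccc(Cl)cc1C(=O)c1ccccc1`): in this assay compound 2 gives 71 mg/kg.

Within the data shown here, of these two numbers, compound 2 stands highest; its only neighbour, compound 1, sits lower by a gap beyond the usual scatter. Compound 3 (`Cc1nnc(CN(C)C)n1-c1ccc(Cl)cc1C(=O)c1ccccc1`) differs from compound 2 by methyl in place of furan-2-yl on an aromatic carbon. Among the measured compounds shown here, no measured pair shows what such a change does here, so no step beyond the scatter is expected in either direction. The estimated step from compound 2 to compound 3 is a 1.2-fold lower number from compound 2 to compound 3 (0.07 log units; within the scatter). Compound 3 is thus expected to give about 60 mg/kg, likely between 25 mg/kg and 150 mg/kg.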

Compound 3, dose for half-maximal effect: 5 mg/kg
Beside the measured number, compound 3's estimate is 12-fold (1.08 log units) above it; measured number below the stated range.
By their numbers in this assay, from the lowest: compound 3; then compound 1; then compound 2.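

The group on this aromatic carbon, between two ring nitrogen atoms, matters a great deal in this assay: methyl in place of furan-2-yl gives a 14-fold lower number from compound 2 to compound 3 (1.15 log units; beyond the scatter). The position is therefore far from indifferent, and here the group with one heavy atom needs less compound than the five-atom ring. Nothing available explains why the step is so large.

As far as these compounds go, with only these two groups at this place, it remains open whether ring loss or group size counts. An ethyl group, a phenyl ring or an amine here could separate the two.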